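A few compounds are considered here, and "the series" means these few. Any claim that something is new, unique, unknown or untested is made for them only; others in the source may bear on it.

In an assay on cells for inhibition of Amine oxidase [flavin-containing] B (Homo sapiens), read by fluorescence, spectrophotometry and Amplex Red, with stated times of 60 min and 30 min (on this read-out lower numbers stand for stronger inhibition and higher numbers for weaker inhibition), compound 1 `CN(C)CCC(=O)c1cc2ccc(O)cc2oc1=O` gives 71400 nM. Compound 2 `O=C(CCN1CCCCC1)c1cc2ccc(O)cc2oc1=O` reaches only the limit of this assay, > 200000 nM, a limit rather than a number (the limit of > 200000 nM in this assay, at which 1 of the 3 values shown sits). Compound 3 `COc1ccc2cc(C(=O)CCN(C)C)c(=O)oc2c1` gives 21100 nM, the lower of the two numbers shown, with compound 1 the nearest to it. That gap is the step of a 3.4-fold lower number from compound 1 to compound 3 (0.53 log units; beyond the scatter). Compound 4 `COc1ccc2cc(C(=O)CCN3CCCCC3)c(=O)oc2c1` carries the change piperidin-1-yl in place of dimethylamino on a saturated chain carbon, two bonds along the chain from a carbonyl carbon onto the core of compound 3. The same change has been made once before, as the step of an at least 2.8-fold higher number from compound 1 to compound 2 (0.44 log units; beyond the scatter), and that step bears directly on this one. For compound 4 a step of similar direction and size is therefore expected, a 3.3-fold higher number from compound 3 to compound 4 (0.52 log units; beyond the scatter), with some chance that only a limit is reported again. Compound 4 is expected to give about 70000 nM, between 30000 nM and 200000 nM.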

Compound 4, half-maximal inhibitory concentration: 20100 nM
Compound 4: middle estimate off by 3.5-fold (0.54 log units), on the high side, and the stated range ends above it.
By their numbers in this assay, from the lowest: compounds 4 and 3 (each within the scatter of the next); then compound 1. At a limit, above all of these: compound 2.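

On the methylated core, piperidin-1-yl and dimethylamino cannot be told apart, a 1.0-fold lower number from compound 3 to compound 4 (0.02 log units; within the scatter), so the loss seen on the core with the free hydroxyl does not carry over: the same change on two cores in this assay, an at least 2.8-fold higher number (0.44 log units; beyond the scatter) from compound 1 to compound 2 and a 1.0-fold lower number (0.02 log units; within the scatter) from compound 3 to compound 4, at least 2.9-fold (0.46 log units) apart, beyond the scatter of two such steps The methyl on the ring oxygen also counts for more with piperidin-1-yl, an at least 9.9-fold lower number from compound 2 to compound 4 (0.99 log units; beyond the scatter), than with dimethylamino: the same change on two cores in this assay, a 3.4-fold lower number (0.53 log units; beyond the scatter) from compound 1 to compound 3 and an at least 9.9-fold lower number (0.99 log units; beyond the scatter) from compound 2 to compound 4, at least 2.9-fold (0.46 log units) apart, beyond the scatter of two such steps Compound 2 remains a limit, > 200000 nM, and not a number.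

On these data alone, it remains open whether another cyclic amine, such as morpholine or pyrrolidine, would also match dimethylamino on this core. The effect of a longer chain to the amine is also unknown.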